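Removing the Bromine from Compound 3

A few compounds are considered here, and "the series" means these few. Any claim that something is new, unique, unknown or untested is made for them only; others in the source may bear on it.

Compound 1 `CN(C)C(=O)c1cc2cnc(Nc3ccc(NC(=O)C4(C(=O)Nc5ccc(F)cc5)CC4)cc3)nc2n1C1CCCC1` gives 36.5%
Compound 2 `CN(C)C(=O)c1cc2cnc(Nc3ccc(NC(=O)C4(C(=O)Nc5ccccc5F)CC4)cc3)nc2n1C1CCCC1` gives 63.4%
Compound 3 `CN(C)C(=O)c1cc2cnc(Nc3ccc(NC(=O)C4(C(=O)Nc5cccc(Br)c5)CC4)cc3)nc2n1C1CCCC1` gives 13.9%

In a functional assay on SiHa cells (Homo sapiens) for inhibition, read by CCK-8 assay, with a stated time of 72 h, tested at 1 uM (on this read-out higher numbers stand for more inhibition of growth at the one concentration tested and lower numbers for less inhibition of growth), compound 3 stands lowest of the three at 13.9% and is the starting point here. Compound 4 `CN(C)C(=O)c1cc2cnc(Nc3ccc(NC(=O)C4(C(=O)Nc5ccccc5)CC4)cc3)nc2n1C1CCCC1` differs from it by one change: hydrogen in place of bromo on an aromatic carbon. For the measured compounds named here, no measured step removes a group from this ring, so the evidence is indirect. The closest guides are a number 22.6 percentage points lower from compound 1 to compound 3 (beyond the scatter) and a number 49.5 percentage points lower from compound 2 to compound 3 (beyond the scatter), both beyond the scatter. The step of a number 26.9 percentage points higher from compound 1 to compound 2 (beyond the scatter) shows how far values spread among these analogues. An upward move of moderate size is expected, with an estimated step of a number 26.1 percentage points higher from compound 3 to compound 4 (beyond the scatter). Compound 4 is estimated at 40%, with an expected range from 20% to 62%.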

Compound 4, percent growth inhibition at one concentration: 58%
Compound 4: middle estimate off by 18 percentage points, on the low side; measured number inside the range.
By their numbers in this assay, from the lowest: compound 3; then compound 1; then compounds 4 and 2 (each within the scatter of the next).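

In this assay, the unsubstituted phenyl shows that the bromo carries a heavy cost at this position, with a number 44.1 percentage points higher from compound 3 to compound 4 (beyond the scatter) on its loss. Fluoro behaves differently according to where it sits: a number 5.4 percentage points lower from compound 2 to compound 4 (within the scatter) leaves 2-fluorophenyl and phenyl indistinguishable, while a number 21.5 percentage points higher from compound 1 to compound 4 (beyond the scatter) places 4-fluorophenyl beyond the scatter under phenyl. None of these three halogen-bearing rings stands beyond the scatter above the bare ring.

From the compounds shown here alone, whether a methoxy group or an amine on this ring could surpass phenyl remains open. Nothing given here explains why the bromo and the 4-fluoro lower the number.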